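The source may hold more compounds than are shown below. What is called first, only, known or untested is meant among the compounds shown, and "the series" means these compounds.

Compound 1 `COc1cc(-c2cc3nccc(-c4c[nH]c5ccccc45)n3n2)cc(OC)c1OC` gives > 10000 nM (a limit)
Compound 2 `COc1cc(-c2ccnc3cc(-c4ccc(C)cc4)nn23)cc(OC)c1OC` gives 48 nM
Compound 3 `Cn1ccc2cc(-c3cc4nccc(-c5ccc(F)cc5)n4n3)ccc21` gives 2160 nM

The two actual numbers lie beyond the scatter of each other: in a functional assay on HCT-116 cells (Homo sapiens) for inhibition, read by CCK-8 assay, with a stated time of 48 h (a lower number here means a stronger inhibitor, a higher number a weaker inhibitor), compound 2 holds the lower (48 nM) and compound 3 the higher (2160 nM). Compound 1 gives a limit and not a number (> 10000 nM).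

Compound 4 `COc1cc(-c2ccnc3cc(-c4cn(C)c5ccccc45)nn23)cc(OC)c1OC` has not yet been measured. It differs from compound 2 by one change (1-methyl-1H-indol-3-yl in place of 4-methylphenyl on an aromatic carbon): 1-methyl-1H-indol-3-yl in place of 4-methylphenyl on an aromatic carbon. Among the compounds with values here, no measured pair shows this change, so, starting from compound 2 (48 nM), no step beyond the scatter is expected, though with wide uncertainty. The estimated change is small (a 1.2-fold lower number from compound 2 to compound 4 (0.08 log units; within the scatter)). Compound 4 is estimated at 40 nM (expected range 10 nM to 300 nM).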

Compound 4, half-maximal inhibitory concentration: 762 nM
Compound 4: middle estimate off by 19-fold (1.28 log units), on the low side; the measured number lies above the stated range.
By their numbers in this assay, from the lowest: compound 2; then compound 4; then compound 3. At a limit, above all of these: compound 1.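

In this assay, the aromatic carbon of the five-membered ring is not indifferent to the group it carries: 1-methyl-1H-indol-3-yl in place of 4-methylphenyl gives a 16-fold higher number from compound 2 to compound 4 (1.20 log units; beyond the scatter). This is the first comparison among these compounds that differs in one place only, and it shows that the two-ring group is the weaker of the two here. Nothing shown accounts for the size of this step. On these data alone, how a 4-methoxyphenyl, a 4-chlorophenyl or a pyridine ring would read at this position stays open, as does whether the same change would cost as much on another core.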